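One Group Exchanged on Compound 1

The compounds below may be only part of what the source reports. "The series", "measured", "known", "first", "only" and "open" are said of these compounds alone.

Among the compounds with values here, in an ADME assay on the whole organism (Mus musculus) for metabolic stability, at a dose of 10 mg/kg by the oral route (on this read-out lower numbers stand for a shorter-lived compound and higher numbers for a longer-lived compound), compound 1 `CN(Cc1ccccc1)S(=O)(=O)c1ccc(NC(=O)NCc2ccncc2)cc1` gives 0.6 h, the lower of the two numbers so far, while compound 2 `O=C(NCc1cn[nH]c1)Nc1ccc(S(=O)(=O)c2ccccc2)cc1` gives 2.5 h. Compound 2 differs from compound 1 in more than one place, so it offers no clean guide. Compound 3 `O=C(NCc1ccncc1)Nc1ccc(S(=O)(=O)N2CCc3ccccc3C2)cc1` carries 1,2,3,4-tetrahydroisoquinolin-2-yl in place of benzyl(methyl)amino on a sulfonyl sulfur. Within the data shown here, no measured pair shows this exchange, so only a modest shift is expected. The estimated 1.3-fold higher number from compound 1 to compound 3 (0.12 log units; within the scatter) stays within the usual scatter. The expected value for compound 3 is 0.8 h, with a range of 0.3 h to 2 h.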

Compound 3, half-life: 1 h
The estimate for compound 3 lay 1.3-fold (0.10 log units) below the measured number; measured number inside the range.
By their numbers in this assay, from the lowest: compounds 1 and 3 (each within the scatter of the next); then compound 2.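

Exchanging benzyl(methyl)amino for 1,2,3,4-tetrahydroisoquinolin-2-yl on a sulfonyl sulfur gives a 1.7-fold higher number from compound 1 to compound 3 (0.22 log units; within the scatter) in this assay. At this position, then, tying the benzyl group into a ring leaves the half-life indistinguishable from that of compound 1, and the short half-life of compound 1 cannot be separated from this single change. Nothing measured here offers a reason for this result. From the compounds shown here alone, whether a simple dimethylamino or a morpholin-4-yl group on the same sulfur would move the half-life beyond the scatter remains open.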